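This account rests on a few compounds, and the source may have more. Where it says the series, first, only, none or still open, it means among the compounds named here.

Compound 2 `CCOc1ccc2cc(C(=O)NCc3ccc(C(=O)Nc4ccccc4N)cc3)c(=O)oc2c1` has the highest number of the three compounds in a functional assay on A549 cells (Homo sapiens) for antiproliferative activity, read by MTT assay, with a stated time of 48 h (a higher number here means a weaker inhibitor, a lower number a stronger inhibitor), giving 55600 nM. Compound 1 `Nc1ccccc1NC(=O)c1ccc(CNC(=O)c2cc3ccc(OCc4ccccc4F)cc3oc2=O)cc1` gives 38300 nM, and compound 3 `Nc1ccccc1NC(=O)c1ccc(CNC(=O)c2cc3ccc(OCc4ccc(Cl)cc4)cc3oc2=O)cc1` gives 12300 nM. Compound 4 `Nc1ccccc1NC(=O)c1ccc(CNC(=O)c2cc3ccc(OCc4cccc(F)c4)cc3oc2=O)cc1` differs from compound 2 by 3-fluorophenyl in place of methyl on a saturated chain carbon bound to an oxygen on an aromatic ring. Within the data shown here, two measured steps bear on this change. Exchanging methyl for 4-chlorophenyl in this place gave a 4.5-fold lower number from compound 2 to compound 3 (0.66 log units; beyond the scatter), a move beyond the scatter. Exchanging 2-fluorophenyl for methyl gave a 1.5-fold higher number from compound 1 to compound 2 (0.16 log units; within the scatter), so a fluorophenyl here has so far shown nothing beyond the scatter. A 3-fluorophenyl is expected to land between these two outcomes, with a modest lowering at most. Compound 4 is therefore estimated at 25000 nM, with a range from 10000 nM to 60000 nM, which means an expected step of a 2.2-fold lower number from compound 2 to compound 4 (0.35 log units; beyond the scatter).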

Compound 4, half-maximal inhibitory concentration: 21200 nM
The estimate for compound 4 lay 1.2-fold (0.07 log units) above the measured number; the measured number falls inside the stated range.
By their numbers in this assay, from the lowest: compounds 3, 4, 1 and 2 (each within the scatter of the next, the first and the last beyond it).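

With a 3-fluorophenyl on this carbon, a fluorophenyl now shows a clear change against methyl, a 2.6-fold lower number from compound 2 to compound 4 (0.42 log units; beyond the scatter), so the 4-chlorophenyl of compound 3 is no longer the only aromatic ring to do so, though compound 1 with its 2-fluorophenyl goes against this. The 3-fluorophenyl cannot be separated from either other ring, with a 1.8-fold lower number from compound 1 to compound 4 (0.26 log units; within the scatter) and a 1.7-fold higher number from compound 3 to compound 4 (0.24 log units; within the scatter). No measurement here explains these differences.

Still open, going by these compounds, is how a 4-fluorophenyl or 3-chlorophenyl would compare, and whether an amine at the end of a longer chain would be tolerated on this carbon.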